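Sulfation pattern and fibroblast growth factor 2 binding

The source may hold more compounds than are shown below. What is called first, only, known or untested is meant among the compounds shown, and "the series" means these compounds.

Measured so far:
compound 1 `CC(=O)N[C@H]1[C@@H](OC[C@@H](O)[C@@H](O)[C@H](O)[C@@H](O)CNc2cccc(NC(=O)CCCCC3CCSS3)c2)O[C@H](CO)[C@H](OS(=O)(=O)O)[C@@H]1O[C@@H]1O[C@H](C(=O)O)[C@@H](O)[C@H](O)[C@H]1OS(=O)(=O)O`, 41 nM
compound 2 `CC(=O)N[C@H]1[C@@H](OC[C@@H](O)[C@@H](O)[C@H](O)[C@@H](O)CNc2cccc(NC(=O)CCCCC3CCSS3)c2)O[C@H](CO)[C@H](OS(=O)(=O)O)[C@@H]1O[C@@H]1O[C@H](C(=O)O)[C@@H](O)[C@H](OS(=O)(=O)O)[C@H]1O`, 41 nM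
compound 3 `CC(=O)N[C@H]1[C@@H](OC[C@@H](O)[C@@H](O)[C@H](O)[C@@H](O)CNc2cccc(NC(=O)CCCCC3CCSS3)c2)O[C@H](CO)[C@H](O)[C@@H]1O[C@@H]1O[C@H](C(=O)O)[C@@H](O)[C@H](OS(=O)(=O)O)[C@H]1OS(=O)(=O)O`, 95 nM

In an assay on isolated protein for binding affinity to fibroblast growth factor 2 (Homo sapiens), read by surface plasmon resonance (on this read-out lower numbers stand for tighter binding and higher numbers for weaker binding), compound 1 gives 41 nM and compound 2 gives 41 nM; these two numbers lie within the scatter of each other. Compound 3 gives 95 nM, the highest of the three numbers, and its gap to compound 1 and to compound 2 is beyond the scatter, so compound 3 is the weakest binder among the measured set.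

Compound 4 `CC(=O)N[C@H]1[C@@H](OC[C@@H](O)[C@@H](O)[C@H](O)[C@@H](O)CNc2cccc(NC(=O)CCCCC3CCSS3)c2)O[C@H](CO)[C@H](OS(=O)(=O)O)[C@@H]1O[C@@H]1O[C@H](C(=O)O)[C@@H](O)[C@H](OS(=O)(=O)O)[C@H]1OS(=O)(=O)O` has not been measured. It differs from compound 3 by sulfo in place of hydrogen on an oxygen on a saturated carbon, that is, hydroxy to sulfooxy on a saturated carbon whose other neighbour is a saturated ring carbon. Compounds 1 and 2 both carry that sulfooxy group and both give lower numbers than compound 3; on that basis the step from compound 3 to compound 4 is expected to lower the number beyond the scatter, with a 2.7-fold lower number from compound 3 to compound 4 (0.43 log units; beyond the scatter) as the estimated size. For compound 4 the expected value in this assay is 35 nM, with a range from 15 nM to 80 nM.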

Compound 4, dissociation constant: 52 nM
Compound 4: middle estimate off by 1.5-fold (0.17 log units), on the low side; measured number inside the range.
By their numbers in this assay, from the lowest: compounds 1, 2, 4 and 3 (each within the scatter of the next, the first and the last beyond it).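

Working notes on the series: in this assay, hydroxy to sulfooxy on an oxygen on a saturated carbon whose other neighbour is a saturated ring carbon gives a 1.8-fold lower number from compound 3 to compound 4 (0.26 log units; within the scatter) and does not separate the pair at this position. The same sulfo-for-hydrogen change at the other two places gives a 1.3-fold higher number from compound 1 to compound 4 (0.10 log units; within the scatter) and a 1.3-fold higher number from compound 2 to compound 4 (0.10 log units; within the scatter), so none of the three single changes leading to compound 4 is beyond the scatter. Adding sulfooxy at any one of these places therefore shows no readable step in this series.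

Going by these compounds, whether a group other than sulfooxy at this position, such as methoxy or an amine, would give a step beyond the scatter remains open. Nothing shown bears on what lies behind these numbers.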